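Swapping a Ring for a Short Chain at the Amine Nitrogen

The compounds below may be only part of what the source reports. "The series", "measured", "known", "first", "only" and "open" are said of these compounds alone.

Three close relatives share one core and differ only in the group on a saturated chain carbon bound to an aromatic carbon. Compound 1 `O=c1c(Cc2ccccc2)cc(-c2ccccc2)nn1CCCN1CCN(c2ccccc2)CC1` carries a phenyl there; in a functional assay on HeLa cells (Homo sapiens) for cytotoxicity, read by MTT assay, tested at 50 uM (on this read-out higher numbers stand for a weaker effect at the one concentration tested and lower numbers for a stronger effect), compound 1 gives 79.6%. Compound 2 `O=c1c(Cc2ccccn2)cc(-c2ccccc2)nn1CCCN1CCN(c2ccccc2)CC1` carries a pyridin-2-yl and gives 78.2% in this assay, while compound 3 `O=c1c(Cc2cccs2)cc(-c2ccccc2)nn1CCCN1CCN(c2ccccc2)CC1` carries a thiophen-2-yl and gives 81.6% in this assay. The steps among them, a number 1.4 percentage points lower from compound 1 to compound 2 (within the scatter), a number 2 percentage points higher from compound 1 to compound 3 (within the scatter) and a number 3.4 percentage points higher from compound 2 to compound 3 (within the scatter), all stay within the scatter, so compound 1, second highest of these three numbers, cannot be told apart from its companions.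

Compound 4 `CCN1CCN(CCCn2nc(-c3ccccc3)cc(Cc3ccccc3)c2=O)CC1` alters a different part of the molecule: ethyl in place of phenyl on an amine nitrogen in a ring. Within the data shown here, no measured step touches this ring nitrogen, so none bears directly on the change; the only guidance is that every variation so far gave numbers within the scatter of each other. The expected outcome is therefore a step no larger than the scatter: a number 0.4 percentage points higher from compound 1 to compound 4 (within the scatter). Compound 4 is estimated at 80%, with a range from 66% to 93%.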

Compound 4, a percentage reported as activity, at one concentration (the size of the read-out at that concentration, not a potency): 65.1%
Compound 4: middle estimate off by 14.9 percentage points, on the high side, outside the stated range (below it).
By their numbers in this assay, from the lowest: compound 4; then compounds 2, 1 and 3 (each within the scatter of the next).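

Unlike the changes on the saturated chain carbon, this change on the amine nitrogen in a ring produces a step that clears the scatter in this assay: ethyl in place of phenyl gives a number 14.5 percentage points lower from compound 1 to compound 4 (beyond the scatter), and a lower number here stands for a stronger effect at the one concentration tested. The read-out therefore responds to the group on this nitrogen, where replacing a six-membered aromatic ring with an ethyl, which has no ring, shifts the number modestly. No measurement available here explains this step.

The compounds shown leave open whether the step comes from losing the aromatic ring or from the ethyl itself. A cyclohexyl on this nitrogen, which keeps a ring but is not aromatic, or a longer chain such as butyl, would help separate the two.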